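Imine series: whole-animal inhibition, cyclopropyl to phenyl

The source may hold more compounds than are shown below. What is called first, only, known or untested is meant among the compounds shown, and "the series" means these compounds.

Of the compounds shown here, two have numbers so far. Compound 1 `c1ccc(C(/N=C2\CCCCCN2)C2CCCCCC2)cc1` gives 6% in a functional assay on the whole organism (plasma, strain Sprague-Dawley) with Rattus norvegicus as the target, with a stated time of 2 h, at a dose of 100 mg/kg by the oral route; a higher number here means a stronger effect of the compound at the dose given, a lower number a weaker effect. Compound 2 `c1csc(C(/N=C2\CCCCCN2)C2CC2)c1` gives 44% in this assay. Compound 2 thus stands highest of the two numbers shown, and its nearest neighbour is compound 1, whose number is lower by a gap that lies beyond the scatter. The two compounds differ in more than one place, so their values are compared only as values and no single change is read from them.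

Compound 3 `c1ccc(C(/N=C2\CCCCCN2)c2cccs2)cc1` is not yet measured in this assay. It differs from compound 2 in one place: phenyl in place of cyclopropyl on a saturated chain carbon bound to an aromatic carbon and a double-bonded nitrogen

For the measured compounds named here, no measured pair shows this change directly, so its size is open. The expectation is a downward step from compound 2 to compound 3 of a number 19 percentage points lower from compound 2 to compound 3 (beyond the scatter), because compound 1, which also carries a phenyl on that chain carbon, gives 6%, though compound 1 differs in a second place as well. The estimate for compound 3 in this assay is 25%, with a range from 5% to 50%.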

Compound 3, a percentage reported as inhibition, in the whole organism at one dose (the size of the read-out at that dose, not a potency): 50%
Beside the measured number, compound 3's estimate is 25 percentage points below it; measured number inside the range.
By their numbers in this assay, from the lowest: compound 1; then compounds 2 and 3 (each within the scatter of the next).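

In this assay the exchange of cyclopropyl for phenyl on a saturated chain carbon bound to an aromatic carbon and a double-bonded nitrogen gives a number 6 percentage points higher from compound 2 to compound 3 (within the scatter) and so, with thiophen-2-yl as the other group on that carbon, this read-out does not separate a three-membered non-aromatic ring from a six-membered aromatic ring. For the compounds shown here, the same place also carries the first large single-place step, thiophen-2-yl in place of cycloheptyl with phenyl retained, which gives a number 44 percentage points higher from compound 1 to compound 3 (beyond the scatter) and shows that a phenyl on this carbon does not by itself go with a low number. Nothing at hand explains either step.

Still open, as far as these compounds go, is whether thiophen-2-yl is itself required, or whether a pyridyl ring or a plain methyl group in its place would hold the number with phenyl retained on the chain carbon. Also open, from the compounds shown here alone, is how an open-chain group such as isopropyl would compare with cyclopropyl and cycloheptyl at this place, and whether the numbers at this single dose would hold at other doses.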